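Phenyl for Methyl on a Core That Shows Only Limits

This account rests on a few compounds, and the source may have more. Where it says the series, first, only, none or still open, it means among the compounds named here.

Measured compounds:
compound 1 `CCC(=O)c1ccc2c(c1O)[C@@H]1c3c(ccc4c(=O)c(C)c(C)oc34)OC[C@@H]1C(C)(C)O2` > 100000 nM
compound 2 `CC(=O)c1ccc2c(c1O)[C@@H]1c3c(ccc4c(=O)c(C)c(C)oc34)OC[C@@H]1C(C)(C)O2` > 100000 nM

In a functional assay on MCF7 cells (Homo sapiens) for cytotoxicity, read by MTT assay (on this read-out lower numbers stand for stronger inhibition and higher numbers for weaker inhibition), compound 1 reaches only > 100000 nM, which is a limit of the assay and not a number. Compound 2 likewise ends at the limit > 100000 nM. The step that the two limits leave unreadable from compound 1 to compound 2 therefore cannot be read, since (the limit of > 100000 nM in this assay, at which 2 of the 2 values shown sit). Compound 3 `CCC(=O)c1ccc2c(c1O)[C@@H]1c3c(ccc4c(=O)c(-c5ccccc5)c(C)oc34)OC[C@@H]1C(C)(C)O2` carries the change (phenyl in place of methyl on an aromatic carbon). For the measured compounds named here, no measured step touches a phenyl in place of methyl, so nothing here fixes the direction of the step; the step of a number no higher from compound 1 to compound 3 (the limit leaves the size open) is only an estimate. Compound 3 is expected to give about 100000 nM, between 30000 nM and 300000 nM, most likely again as a limit.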

Compound 3, half-maximal inhibitory concentration: 20500 nM
Estimate against measurement, compound 3: 4.9-fold (0.69 log units) above; the measured number lies below the stated range.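

In this assay, compound 3 is the only compound shown that gives a number and not a limit, so a read-out on the shared core becomes possible with phenyl on this aromatic carbon, two atoms from the ring oxygen. Phenyl in place of methyl here brings an at least 4.8-fold lower number from compound 1 to compound 3 (0.68 log units; beyond the scatter). The full size of this step stays open because compound 1 carries only a limit: the limit of > 100000 nM in this assay, at which 2 of the 3 values shown sit.

On these data alone, it remains open whether a smaller group such as ethyl, or an amine, at this carbon would also give a number. Also open, as far as these compounds go, is whether phenyl would do the same on compound 2.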